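The source may hold more compounds than are shown below. What is called first, only, known or untested is meant among the compounds shown, and "the series" means these compounds.

Working notes on the amide series built on the shared core of compound 1 `O=C(Nc1ccc(Cl)c(-c2nnc3c(Cl)cccn23)c1)c1ccc(C(F)(F)F)cc1Cl`. In a functional assay on MDA-MB-468 cells (Homo sapiens) for antiproliferative activity, read by MTT assay, with a stated time of 72 h (on this read-out lower numbers stand for stronger inhibition and higher numbers for weaker inhibition), compound 1 gives > 100000 nM, which is a limit of the assay rather than a number. Compound 2 `O=C(Nc1ccc(Cl)c(-c2nnc3c(Cl)cccn23)c1)c1ccc(Cl)cc1` in this assay also returns a limit, > 100000 nM. Compound 3 `O=C(Nc1ccc(Cl)c(-c2nnc3c(Cl)cccn23)c1)c1ccc(C(F)(F)F)cc1F` in this assay gives 22300 nM. Among the compounds with values here, the single measured step that ends in a number, an at least 4.4-fold lower number from compound 1 to compound 3 (0.65 log units; beyond the scatter), concerns a different place on the structure from the change considered here, so compound 1 stands at the limit of > 100000 nM in this assay, at which 2 of the 3 values shown sit, and offers no measured step that bears on its trifluoromethyl group. Compound 4 `CS(=O)(=O)c1ccc(C(=O)Nc2ccc(Cl)c(-c3nnc4c(Cl)cccn34)c2)c(Cl)c1` carries methylsulfonyl in place of trifluoromethyl on an aromatic carbon. Within the data shown here, no measured pair involves a methylsulfonyl group, so no size of step in this assay can be read from the measured compounds, and a number for compound 1 itself is lacking. Compound 4 is therefore expected to stay near the limit, with an estimated value of 80000 nM and an estimated range from 15000 nM to 300000 nM. This estimate corresponds to an expected step of an at least 1.2-fold lower number from compound 1 to compound 4 (0.09 log units; that floor lies within the scatter).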

Compound 4, half-maximal inhibitory concentration: > 100000 nM
Compound 4: no number, only a limit (the forecaster's own chance of this, stated with the estimate: 60%); at least 1.2-fold (0.09 log units) between middle value and limit.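

In this assay compound 4 gives > 100000 nM, a limit and not a number; compound 1 also stands at a limit, so no step between compound 1 and compound 4 can be read: the limit of > 100000 nM in this assay, at which 3 of the 4 values shown sit.

On these data alone, whether methylsulfonyl in place of trifluoromethyl changes the antiproliferative activity at all remains open.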